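Benzylsulfanyl in place of methylsulfanyl: compound 3

This account rests on a few compounds, and the source may have more. Where it says the series, first, only, none or still open, it means among the compounds named here.

Measured compounds:
compound 1 `CSc1nnc(Cc2ccccc2Oc2ccccc2)[nH]1` in a functional assay on the whole organism (strain NMRI) with Mus musculus as the target, with a stated time of 60 min, at a dose of 5 mg/kg by the intraperitoneal route; on this read-out higher numbers stand for a stronger effect at the one dose given and lower numbers for a weaker effect: 120%
compound 2 `CSc1nnc(Cc2ccc(Cl)cc2Oc2ccccc2Cl)[nH]1` in this assay: 125%

Compound 2 holds the top number of the two, yet the gap to compound 1 lies within the scatter, so the two compounds cannot be told apart on this read-out. For the measured compounds named here, no step between measured compounds is available that differs in a single place, so nothing is known about how any one change moves the number in this assay.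

Compound 3 `Clc1ccc(Cc2nnc(SCc3ccccc3)[nH]2)c(Oc2ccccc2Cl)c1` is not yet measured. It differs from compound 2 in one place: phenyl in place of hydrogen on a saturated chain carbon bound to a sulfur. The shared core of compound 2 and compound 3 stays the same, as does the rest of the substitution on the two aromatic rings of compound 2.

Going by the values given here, since no comparable step is at hand, the expectation for the step from compound 2 to compound 3 rests on the two measured numbers alone: both stand high, and a change of this kind is expected to give no step beyond the scatter, with a slight downward lean, so that a number 10 percentage points lower from compound 2 to compound 3 (within the scatter) is estimated. For compound 3 the estimate in this assay is 115%, in the range 85% to 140%.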

Compound 3, a percentage reported as activity, at one dose (the size of the read-out at that dose, not a potency): 113%
For compound 3 the middle estimate is 2 percentage points above the measured one; low and high end bracket the measured number.
By their numbers in this assay, from the lowest: compounds 3, 1 and 2 (each within the scatter of the next, the first and the last beyond it).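

The methylsulfanyl position now has its first step between compounds that differ in one place: in this assay, the change from methylsulfanyl to benzylsulfanyl gives a number 12 percentage points lower from compound 2 to compound 3 (beyond the scatter) as a modest step. The read-out is reduced but not lost, since compound 3 still gives 113% with a phenyl on the saturated chain carbon bound to the sulfur, so this position accepts a group of 6 further heavy atoms at the one dose given. No measurement at hand bears on why the number falls.

This single step, taken on one parent at one dose, does not separate an effect of the phenyl ring from an effect of chain length, and the compounds shown do not tell whether the same change would move the number to a similar extent on compound 1, which carries no chlorine. Also open, going by these compounds, is how the read-out would respond to an ethyl or longer alkyl chain, to a chlorobenzyl group, or to a chain ending in an amine or a carboxylic acid at this sulfur.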